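The source may hold more compounds than are shown below. What is called first, only, known or untested is meant among the compounds shown, and "the series" means these compounds.

Measured compounds in an assay on isolated protein for binding affinity to secreted frizzled-related protein 1 (Homo sapiens), read by fluorescence; on this read-out lower numbers stand for stronger inhibition and higher numbers for weaker inhibition:
compound 1 `O=C1CC[C@@H](C(=O)N2CCC(NS(=O)(=O)c3cc(S(=O)(=O)c4ccccc4)ccc3C(F)(F)F)CC2)N1` — 90 nM
compound 2 `CC(=O)N1CCC[C@H]1C(=O)N1CCC(NS(=O)(=O)c2cc(S(=O)(=O)c3ccccc3)ccc2C(F)(F)F)CC1` — 160 nM
compound 3 `CCNC(=O)N1CCC[C@H]1C(=O)N1CCC(NS(=O)(=O)c2cc(S(=O)(=O)c3ccccc3)ccc2C(F)(F)F)CC1` — 30 nM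

On these numbers compound 1 stands second highest of the three. Its nearest neighbour is compound 2, with a 1.8-fold higher number from compound 1 to compound 2 (0.25 log units; within the scatter); its furthest is compound 3, with a 3.0-fold lower number from compound 1 to compound 3 (0.48 log units; beyond the scatter).

Compound 4 `CC(C)(C)NC(=O)N1CCC[C@H]1C(=O)N1CCC(NS(=O)(=O)c2cc(S(=O)(=O)c3ccccc3)ccc2C(F)(F)F)CC1` differs from compound 1 as follows: 1-((tert-butyl)carbamoyl)pyrrolidin-2-yl in place of 5-oxopyrrolidin-2-yl on a carbonyl carbon. Going by the values given here, two measured steps bear on this change. Replacing the 5-oxopyrrolidin-2-yl group by an ethylcarbamoyl-bearing pyrrolidine gave a 3.0-fold lower number from compound 1 to compound 3 (0.48 log units; beyond the scatter), and exchanging methyl for ethylamino on the carbonyl carbon gave a 5.3-fold lower number from compound 2 to compound 3 (0.73 log units; beyond the scatter). Among the compounds with values here, no measured pair compares a tert-butyl urea with an ethyl urea, so the estimate leans on compound 3 at 30 nM and anticipates a modest lowering, a 2.6-fold lower number from compound 1 to compound 4 (0.41 log units; beyond the scatter). Compound 4 is therefore expected near 35 nM, within 12 nM to 100 nM.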

Compound 4, half-maximal inhibitory concentration: 20 nM
Beside the measured number, compound 4's estimate is 1.8-fold (0.24 log units) above it, and the stated range covers the measured number.
By their numbers in this assay, from the lowest: compounds 4 and 3 (each within the scatter of the next); then compounds 1 and 2 (each within the scatter of the next).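

In this assay, the urea gain over the lactam and the acetyl amide persists with tert-butyl on the amide-type nitrogen: 1-((tert-butyl)carbamoyl)pyrrolidin-2-yl in place of 5-oxopyrrolidin-2-yl gives a 4.5-fold lower number from compound 1 to compound 4 (0.65 log units; beyond the scatter), and (tert-butyl)amino in place of methyl on the carbonyl carbon gives an 8.0-fold lower number from compound 2 to compound 4 (0.90 log units; beyond the scatter). Tert-butyl in place of ethyl gives a 1.5-fold lower number from compound 3 to compound 4 (0.18 log units; within the scatter), so these two ureas cannot be told apart. No available evidence accounts for these differences.

The compounds shown leave open how a phenyl group or a longer chain on that nitrogen would read.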